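Replacing the anilino group of compound 1

A few compounds are considered here, and "the series" means these few. Any claim that something is new, unique, unknown or untested is made for them only; others in the source may bear on it.

Among the measured compounds shown here, in a functional assay on A-375 cells (Homo sapiens) for antiproliferative activity, read by CCK-8 assay, with a stated time of 72 h (on this read-out higher numbers stand for weaker inhibition and lower numbers for stronger inhibition), compound 1 `Nc1ccccc1NC(=O)c1ccc(Cn2cnc3c(Nc4ccccc4)nc(Cl)nc32)cc1` gives 2800 nM, the lowest of the three numbers so far. Compound 2 `Nc1ccccc1NC(=O)c1ccc(Cn2cnc3c(Nc4ccc(-c5ccccn5)cc4)nc(Cl)nc32)cc1` gives 18500 nM and compound 3 `Nc1ccccc1NC(=O)c1ccc(COCNc2nc(Nc3ccccc3)c3ncn(C4CCCC4)c3n2)cc1` gives 8700 nM. Compound 4 `CC1CCN(c2nc(Cl)nc3c2ncn3Cc2ccc(C(=O)Nc3ccccc3N)cc2)CC1` differs from compound 1 as follows: 4-methylpiperidin-1-yl in place of anilino on an aromatic carbon. In words, 4-methylpiperidin-1-yl stands in place of anilino on an aromatic carbon. For the measured compounds named here, no measured compound replaces the anilino group, so the guidance is indirect. Going by the values given here, the one measured step, a 6.6-fold higher number from compound 1 to compound 2 (0.82 log units; beyond the scatter), comes from pyridin-2-yl in place of hydrogen on an aromatic carbon and is modest. In this assay a smaller upward step is therefore expected, estimated as a 2.1-fold higher number from compound 1 to compound 4 (0.33 log units; beyond the scatter). For compound 4 the estimated value is 6000 nM, with an expected range of 1800 nM to 20000 nM.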

Compound 4, half-maximal inhibitory concentration: 4240 nM
Compound 4: the middle estimate sits 1.4-fold (0.15 log units) above what was measured; the measured number falls inside the stated range.
By their numbers in this assay, from the lowest: compounds 1 and 4 (each within the scatter of the next); then compound 3; then compound 2.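

In this assay, 4-methylpiperidin-1-yl can stand in place of anilino on this aromatic carbon of the shared core with a 1.5-fold higher number from compound 1 to compound 4 (0.18 log units; within the scatter). An aromatic carbon ring and the hydrogen-bond donor of anilino are therefore not required at this position to keep compound 4 level with compound 1, whereas adding pyridin-2-yl to the anilino ring gave a 6.6-fold higher number from compound 1 to compound 2 (0.82 log units; beyond the scatter). Nothing measured here accounts for this tolerance. Still open, on these data alone, is whether morpholin-4-yl or an open-chain amine such as diethylamino also stays level with compound 1, and whether the methyl group on the piperidine ring matters.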